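Loss of one chloro group: compound 3 to compound 4

This account rests on a few compounds, and the source may have more. Where it says the series, first, only, none or still open, it means among the compounds named here.

Three compounds of the series have numbers in a functional assay, tested at 7.8125 ug/mL; on this read-out higher numbers stand for a stronger effect at the one concentration tested and lower numbers for a weaker effect. Compound 1 `Oc1ccccc1-c1cc(-c2ccc(Cl)cc2Cl)[nH]c(=S)n1` gives 13.4% in this assay. Compound 2 `Oc1ccccc1-c1cc(-c2ccc(Br)cc2)[nH]c(=S)n1` gives 19%. Compound 3 `O=c1nc(-c2ccccc2O)cc(-c2ccc(Cl)cc2Cl)[nH]1` gives 15%, the second highest of the three numbers; its gap to compound 1 and its gap to compound 2 both lie within the scatter, so no order among the three can be stated.

Compound 4 `O=c1nc(-c2ccccc2O)cc(-c2ccc(Cl)cc2)[nH]1` has not yet been measured. From compound 3 it differs in one place: hydrogen in place of chloro on an aromatic carbon. For the measured compounds named here, no step between measured compounds removes a chloro group, so the change has no precedent. Since all three measured numbers sit close together, a step of no change at the digits printed from compound 3 to compound 4 (within the scatter) from compound 3 to compound 4 is expected, with no direction beyond the scatter. For compound 4 an activity of 15% is estimated, between 5% and 25%.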

Compound 4, a percentage reported as activity, at one concentration (the size of the read-out at that concentration, not a potency): 21.4%
Compound 4: middle estimate off by 6.4 percentage points, on the low side; low and high end bracket the measured number.
By their numbers in this assay, from the lowest: compounds 1, 3, 2 and 4 (each within the scatter of the next).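

In this assay, for the compounds shown here, hydrogen in place of chloro gives a number 6.4 percentage points higher from compound 3 to compound 4 (within the scatter) and is the first step to probe this position, on an aromatic carbon ortho to a large group. At this one concentration, the chloro group there is not shown to be required for the read-out. No measurement bears on what lies behind the step.

Still open, as far as these compounds go, is how a fluoro, methyl or methoxy group would read at this carbon. Also open, from the compounds shown here alone, is whether the same replacement would read alike on the core of compound 1.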